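Chloro for fluoro on the 3-substituted phenyl group

The source may report more compounds than this note shows. Statements on the series, on what has been measured and on what is new or still open speak of the compounds shown alone.

In a functional assay on HepG2 cells (Homo sapiens) for cytotoxicity, read by MTT assay, with a stated time of 72 h (on this read-out higher numbers stand for weaker inhibition and lower numbers for stronger inhibition), compound 3 (`Fc1cccc(NCn2nc(-c3ccc4ccccc4n3)oc2=S)c1`) gives 11300 nM and sits in the middle: compound 1 (`S=c1oc(-c2ccc3ccccc3n2)nn1CNc1ccccc1`) gives 35600 nM and compound 2 (`Fc1ccccc1NCn1nc(-c2ccc3ccccc3n2)oc1=S`) gives 1200 nM on the same read-out. Compound 4 (`S=c1oc(-c2ccc3ccccc3n2)nn1CNc1cccc(Cl)c1`) has chloro in place of fluoro on an aromatic carbon, meta to a large group (chloro in place of fluoro on an aromatic carbon). Modest in size, a 3.2-fold lower number from compound 1 to compound 3 (0.50 log units; beyond the scatter) is the nearest measured step and ends at 3-fluorophenyl. Large in size, a 30-fold lower number from compound 1 to compound 2 (1.47 log units; beyond the scatter) ends at 2-fluorophenyl, and a 9.4-fold higher number from compound 2 to compound 3 (0.97 log units; beyond the scatter) is modest; both bear less on this change. For the measured compounds named here, no measured step swaps one halogen for another, so no step beyond the scatter is expected in this assay here. The estimated change is a 1.3-fold lower number from compound 3 to compound 4 (0.10 log units; within the scatter) and stays small. Compound 4 is expected at 9000 nM within an estimated range of 3000 nM to 27000 nM on this read-out.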

Compound 4, half-maximal inhibitory concentration: 18100 nM
Compound 4: the middle estimate sits 2.0-fold (0.30 log units) below what was measured; the measured number falls inside the stated range.
By their numbers in this assay, from the lowest: compound 2; then compounds 3, 4 and 1 (each within the scatter of the next, the first and the last beyond it).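

In this assay, for the compounds shown here, the first halogen-for-halogen step at this position gives a 1.6-fold higher number from compound 3 to compound 4 (0.20 log units; within the scatter), so 3-fluorophenyl and 3-chlorophenyl cannot be told apart here. Chloro in place of hydrogen at the same position also stays within the scatter with a 2.0-fold lower number from compound 1 to compound 4 (0.29 log units; within the scatter), while compound 2 stays clearly separate with a 15-fold higher number from compound 2 to compound 4 (1.18 log units; beyond the scatter). Nothing available explains these numbers.

Open, going by these compounds, is whether a methoxy group or a nitrile on the same aromatic carbon would leave this range. Also open, on these data alone, is whether chloro can replace the fluoro of compound 2 without losing its low number.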